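The compounds below may be only part of what the source reports. "The series", "measured", "known", "first", "only" and "open" are said of these compounds alone.

Measured in a functional assay on NCI-H23 cells (Homo sapiens) for antiproliferative activity, read by sulforhodamine B assay; a lower number here means a stronger inhibitor of growth, a higher number a weaker inhibitor of growth:
compound 1 `CC(C)=CCOc1cccc(O)c1C(=O)/C=C/c1ccc(O)cc1`: > 30000 nM
compound 2 `CC(C)CCOc1cccc(O)c1C(=O)/C=C/c1ccc(O)cc1`: 12100 nM

Compound 1 gives > 30000 nM, which is a limit of the assay and not a number. For the measured compounds named here, compound 2, at 12100 nM, therefore holds the only actual number in this assay, and no other number exists to rank it against.

Compound 3 `CC(C)COc1cccc(O)c1C(=O)/C=C/c1ccc(O)cc1` has not yet been measured. It carries isopropyl in place of isobutyl on a saturated chain carbon bound to an oxygen on an aromatic ring; cut one bond further out, this reads isopentyloxy to isobutoxy.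

Going by the values given here, one measured step bears on this change, at the same place: an at least 2.4-fold lower number from compound 1 to compound 2 (0.39 log units; beyond the scatter). Among the compounds with values here, it involves a different exchange and rests on a limit, so it shows only that a change here can move the number beyond the scatter. It gives no direction for the present change, and no step beyond the scatter is expected in this assay, though a modest one either way remains possible.

The expected change is a 1.2-fold higher number from compound 2 to compound 3 (0.09 log units; within the scatter). For compound 3 the estimated value is 15000 nM, with an expected range from 6500 nM to 30000 nM.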

Compound 3, concentration for 50% growth inhibition: 3220 nM
Beside the measured number, compound 3's estimate is 4.7-fold (0.67 log units) above it, outside the stated range (below it).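

In this assay, the exchange of isobutyl for isopropyl on a saturated chain carbon bound to an oxygen on an aromatic ring gives a 3.8-fold lower number from compound 2 to compound 3 (0.57 log units; beyond the scatter). This shows that the position responds to a change between two saturated chains, and not only to the loss of 2-methylprop-1-en-1-yl, and that here the shorter isobutoxy chain carries the lower number. The wider comparison gives an at least 9.3-fold lower number from compound 1 to compound 3 (0.96 log units; beyond the scatter), but its true size remains unknown, since it rests on a value that is a limit of the assay and not a number: the limit of > 30000 nM in this assay, at which 1 of the 3 values shown sits.

With only isopentyloxy and isobutoxy as measured saturated chains, a single comparison cannot say whether the number would keep dropping with a shorter chain such as ethoxy or methoxy, or whether isobutoxy already lies near the best length. On these data alone, it also remains open how this position would respond to a branched chain of a different shape, such as cyclopropylmethoxy, or to a chain ending in an amine or a carboxylic acid.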